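The source may report more compounds than this note shows. Statements on the series, on what has been measured and on what is new or still open speak of the compounds shown alone.

Measured so far in a functional assay on T98G cells (Homo sapiens) for cytotoxicity, read by MTT assay; a higher number here means a weaker inhibitor, a lower number a stronger inhibitor:
- compound 1 `Oc1ccc(CN(Cc2ccccc2)Cc2ccc(O)c3ncccc23)c2cccnc12`: 249 nM
- compound 2 `Oc1ccc(CN(Cc2cccc(I)c2)Cc2ccc(O)c3ncccc23)c2cccnc12`: 446 nM

Going by the values given here, compound 2, at 446 nM, lies within the scatter of compound 1, its only neighbour. Compound 3 `Oc1ccc(CN(Cc2cccs2)Cc2ccc(O)c3ncccc23)c2cccnc12` is unmeasured and carries thiophen-2-yl in place of 3-iodophenyl on a saturated chain carbon bound to an amine nitrogen, with thiophen-2-yl in place of 3-iodophenyl. Among the compounds with values here, the one measured step touching this aromatic ring, a 1.8-fold higher number from compound 1 to compound 2 (0.25 log units; within the scatter), is small, but no compound with thiophen-2-yl has been measured, so the basis is thin. The expected change is a 1.5-fold lower number from compound 2 to compound 3 (0.17 log units; within the scatter), which means no step beyond the scatter is expected in this assay. For compound 3 the estimated value is 300 nM, with an expected range of 130 nM to 700 nM.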

Compound 3, half-maximal inhibitory concentration: 88 nM
The estimate for compound 3 lay 3.4-fold (0.53 log units) above the measured number; measured number outside the range, below it.
By their numbers in this assay, from the lowest: compound 3; then compounds 1 and 2 (each within the scatter of the next).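

In this assay, the substituent on a saturated chain carbon bound to an amine nitrogen now shows a step beyond the scatter: thiophen-2-yl gives a 5.1-fold lower number from compound 2 to compound 3 (0.70 log units; beyond the scatter) and a 2.8-fold lower number from compound 1 to compound 3 (0.45 log units; beyond the scatter). The earlier iodo in place of hydrogen stayed within the scatter, so exchanging the whole aromatic ring shows more here than substituting the phenyl ring did. No evidence at hand explains this difference.

From the compounds shown here alone, whether the gain is specific to thiophen-2-yl remains open. Thiophen-3-yl, furan-2-yl or pyridin-2-yl at the same place would test this.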